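Urea to Amide on the Shared Core at Adenosine A3

This account rests on a few compounds, and the source may have more. Where it says the series, first, only, none or still open, it means among the compounds named here.

Measured so far:
compound 1 `O=C(Nc1ccccc1)Nc1nn(-c2ccccc2)c(=O)c2ccccc12` – 178 nM
compound 2 `COc1ccccc1CNC(=O)Nc1nn(-c2ccccc2)c(=O)c2ccccc12` – 274 nM
compound 3 `COc1ccc(NC(=O)Nc2nn(-c3ccccc3)c(=O)c3ccccc23)cc1` – 60.6 nM

In an assay on CHO cells for displacement of a labelled ligand from adenosine receptor A3 (Homo sapiens) (on this read-out higher numbers stand for weaker inhibition and lower numbers for stronger inhibition), compound 2 gives 274 nM, the highest of the three numbers; its nearest neighbour is compound 1, a step of a 1.5-fold higher number from compound 1 to compound 2 (0.19 log units; within the scatter), and its furthest is compound 3, a step of a 4.5-fold lower number from compound 2 to compound 3 (0.66 log units; beyond the scatter). The unmeasured compound 4 `O=C(Nc1nn(-c2ccccc2)c(=O)c2ccccc12)c1ccccc1` differs from compound 2 by phenyl in place of (2-methoxybenzyl)amino on a carbonyl carbon. Among the compounds with values here, no measured step touches the carbonyl carbon in this way: the known steps, a 1.5-fold higher number from compound 1 to compound 2 (0.19 log units; within the scatter) and a 2.9-fold lower number from compound 1 to compound 3 (0.47 log units; beyond the scatter), only exchange groups on the amide-type nitrogen or add methoxy to an aromatic carbon, and they stay within a modest span. The change in compound 4 is therefore of a kind not covered by the measured pairs, and the expectation for compound 4 in this assay is a number near that of compound 2, with a wide range. The estimate for compound 4 is 300 nM, between 60 nM and 1500 nM, which is expected to correspond to a step of a 1.1-fold higher number from compound 2 to compound 4 (0.04 log units; within the scatter).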

Compound 4, inhibition constant: 1100 nM
For compound 4 the middle estimate is 3.7-fold (0.56 log units) below the measured one; the measured number falls inside the stated range.
By their numbers in this assay, from the lowest: compound 3; then compounds 1 and 2 (each within the scatter of the next); then compound 4.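

In this assay, the carbonyl carbon proves sensitive to what sits on it: phenyl in place of (2-methoxybenzyl)amino gives (a 4.0-fold higher number from compound 2 to compound 4 (0.60 log units; beyond the scatter)), phenyl in place of anilino gives (a 6.2-fold higher number from compound 1 to compound 4 (0.79 log units; beyond the scatter)), and phenyl in place of (4-methoxyphenyl)amino gives (an 18-fold higher number from compound 3 to compound 4 (1.26 log units; beyond the scatter)). Within the data shown here, all three steps lie beyond the scatter and point the same way, with the step from compound 3 large and the other two modest, whereas the earlier steps only varied groups on the amide-type nitrogen or added methoxy to an aromatic carbon. No supporting data explain this loss.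

As far as these compounds go, whether a 4-methoxyphenyl, a benzyl or a short alkyl chain attached directly to the carbonyl carbon would match phenyl stays open. So does whether a morpholine or another amine without the amide hydrogen would keep the lower numbers of compound 1 and compound 3.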